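Cytotoxicity notes: from compound 3 to compound 4

The compounds below may be only part of what the source reports. "The series", "measured", "known", "first", "only" and "open" are said of these compounds alone.

Measured so far in a functional assay on SK-N-MC cells (Homo sapiens) for cytotoxicity, read by MTT assay; on this read-out lower numbers stand for stronger inhibition and higher numbers for weaker inhibition:
compound 1 `COc1ccc(/C=C2\CCC/C(=C\c3cccc([N+](=O)[O-])c3)C2=O)cc1`: 10.4 ug/mL
compound 2 `COc1cccc(/C=C2\CCC/C(=C\c3cccc([N+](=O)[O-])c3)C2=O)c1`: 4.94 ug/mL
compound 3 `O=C1/C(=C/c2ccc([N+](=O)[O-])cc2)CCC/C1=C\c1cccc([N+](=O)[O-])c1`: 17.9 ug/mL

Compound 3 carries the highest number of the three in this assay; the gap to compound 1, a 1.7-fold higher number from compound 1 to compound 3 (0.24 log units; within the scatter), lies within the scatter, while the gap to compound 2, a 3.6-fold higher number from compound 2 to compound 3 (0.56 log units; beyond the scatter), lies beyond it. Compound 4 `O=C1/C(=C/c2cccc(Cl)c2)CCC/C1=C\c1cccc([N+](=O)[O-])c1` differs from compound 3 by 3-chlorophenyl in place of 4-nitrophenyl on a double-bonded chain carbon bound to a double-bonded ring carbon. For the measured compounds named here, two measured steps bear on this: a 3.6-fold higher number from compound 2 to compound 3 (0.56 log units; beyond the scatter), which runs through the same place in the opposite sense, and a 2.1-fold lower number from compound 1 to compound 2 (0.32 log units; beyond the scatter), where the substituent shifted on the phenyl ring. Both point toward a lower number for compound 4, so a modest drop, a 2.8-fold lower number from compound 3 to compound 4 (0.44 log units; beyond the scatter), is expected. Compound 4 is estimated at 6.5 ug/mL, with a range from 2.8 ug/mL to 15 ug/mL.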

Compound 4, half-maximal inhibitory concentration: 4.15 ug/mL
Beside the measured number, compound 4's estimate is 1.6-fold (0.19 log units) above it; low and high end bracket the measured number.
By their numbers in this assay, from the lowest: compounds 4 and 2 (each within the scatter of the next); then compounds 1 and 3 (each within the scatter of the next).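

Replacing 4-nitrophenyl with 3-chlorophenyl on a double-bonded chain carbon bound to a double-bonded ring carbon gives a 4.3-fold lower number from compound 3 to compound 4 (0.63 log units; beyond the scatter) and replacing 4-methoxyphenyl with it gives a 2.5-fold lower number from compound 1 to compound 4 (0.40 log units; beyond the scatter), so the 3-chlorophenyl and 3-methoxyphenyl compounds both carry lower numbers than the two 4-substituted compounds. With the ring position kept, chloro in place of methoxy gives a 1.2-fold lower number from compound 2 to compound 4 (0.08 log units; within the scatter), so this read-out does not separate these two groups here. Nothing available accounts for these steps.

Open: whether 4-chlorophenyl would group with the 4-substituted compounds or with the 3-chlorophenyl compound, and whether 3-aminophenyl or 3-carboxyphenyl at this place would keep the lower numbers.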